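The source may hold more compounds than are shown below. What is called first, only, known or untested is meant among the compounds shown, and "the series" means these compounds.

Measured in an assay on HeLa cells for displacement of a labelled ligand from adenosine receptor A3 (Homo sapiens), read by scintillation counting, with a stated time of 180 min, tested at 10 uM; a higher number here means more inhibition at the concentration tested (going by the name of the read-out), a lower number less inhibition:
compound 1, `N=c1oc2ccc(Br)cc2cc1C(=O)NC1CCCCC1`, gives 8%
compound 2, `O=C(NCC(O)CO)c1cc2cc(Cl)ccc2oc1=O`, gives 1%
compound 3, `COc1cccc2cc(C(=O)NCC(O)CO)c(=O)oc12`, gives 1%

Compound 1 holds the highest of the three numbers in this assay, yet its value sits within the scatter of both compound 2 and compound 3, so the three numbers are level and none of them can be called higher than another. Going by the values given here, no pair of measured compounds that differ in a single place is available, and the three show only that each of them displaces little of the labelled ligand at the concentration tested.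

Compound 4, `N=c1oc2ccc(Br)cc2cc1C(=O)NCC(O)CO`, has not yet been measured in this assay. It differs from compound 1 in one way: 2,3-dihydroxypropyl in place of cyclohexyl on an amide-type nitrogen. The same 2,3-dihydroxypropyl on an amide-type nitrogen is carried by compound 2, which gives 1%, and by compound 3, which gives 1% in this assay. On that basis the step is expected to be a number 5 percentage points lower from compound 1 to compound 4 (within the scatter), nothing beyond the scatter. Compound 4 is expected to give 3%, most likely between -7% and 13%.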

Compound 4, a percentage reported as inhibition, at one concentration (the size of the read-out at that concentration, not a potency): 10%
The estimate for compound 4 lay 7 percentage points below the measured number, within the range that was stated.
By their numbers in this assay, from the lowest: compounds 2, 3, 1 and 4 (each within the scatter of the next).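

In this assay, going by these compounds alone, the swap of 2,3-dihydroxypropyl for cyclohexyl on the amide-type nitrogen gives the first comparison in which only one place differs, and it reads a number 2 percentage points higher from compound 1 to compound 4 (within the scatter). On the core of compound 1, then, a six-membered carbon ring and an open 2,3-dihydroxypropyl chain at this position cannot be told apart by this read-out. Nothing measured on these compounds offers an explanation for this lack of separation.

Within the data shown here, whether any group on this nitrogen can lift the inhibition clear of the scatter remains open, since this single pair spans only two groups. A phenyl ring, an aminoethyl chain or a carboxylic acid at the same place might behave differently, and the compounds shown do not say.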